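The source may hold more compounds than are shown below. What is called first, only, known or untested is meant among the compounds shown, and "the series" means these compounds.

Among the compounds with values here, in a functional assay on HeLa cells (Homo sapiens) for cytotoxicity (on this read-out lower numbers stand for stronger inhibition and higher numbers for weaker inhibition), compound 1 (`COC(=O)C1CCC2(CC1)OOC1(CCCCC1)OO2`) gives 75900 nM, level with the only other measured compound, compound 2 (`CCCNC(=O)C1CCC2(CC1)OOC1(CCCCC1)OO2`), at 117000 nM. Compound 3 (`CN(C)CCNC(=O)C1CCC2(CC1)OOC1(CCCCC1)OO2`) differs from compound 1 by (2-(dimethylamino)ethyl)amino in place of methoxy on a carbonyl carbon, with (2-(dimethylamino)ethyl)amino in place of methoxy on a carbonyl carbon. Within the data shown here, the one measured step bearing on this change is propylamino in place of methoxy on a carbonyl carbon, a 1.5-fold higher number from compound 1 to compound 2 (0.19 log units; within the scatter). No step beyond the scatter is therefore expected in this assay, although a single step gives thin support for this side chain. The expected change is a 1.1-fold lower number from compound 1 to compound 3 (0.04 log units; within the scatter). Compound 3 is estimated at 70000 nM, with an expected range of 25000 nM to 180000 nM.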

Compound 3, half-maximal inhibitory concentration: 135000 nM
Beside the measured number, compound 3's estimate is 1.9-fold (0.29 log units) below it; low and high end bracket the measured number.
By their numbers in this assay, from the lowest: compounds 1, 2 and 3 (each within the scatter of the next).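

Both amides now sit level with the ester in this assay: (2-(dimethylamino)ethyl)amino in place of methoxy on the carbonyl carbon gives a 1.8-fold higher number from compound 1 to compound 3 (0.25 log units; within the scatter) and stays within the scatter, as the propylamino change did. Dimethylamino in place of methyl on the saturated chain carbon gives a 1.2-fold higher number from compound 2 to compound 3 (0.06 log units; within the scatter) and also separates nothing. No evidence on the origin of these numbers is at hand.

The compounds shown leave open whether a carboxylic acid or a longer chain ending in morpholine on this carbonyl carbon would move the number beyond the scatter.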